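The source may report more compounds than this note shows. Statements on the series, on what has been measured and on what is new or still open speak of the compounds shown alone.

Measured values in an ADME assay on WI-38 cells (Homo sapiens) for cytotoxicity, read by MTT assay, with a stated time of 72 h; a higher number here means a weaker inhibitor, a lower number a stronger inhibitor
Compound 1 `O=C(CCc1cccc2c1B(O)OC2)Nc1ccccc1` gives 30000 nM
Compound 2 `COc1ccccc1NC(=O)CCc1cccc2c1B(O)OC2` gives 1600 nM

Compound 2 holds the lower of the two numbers. Compound 3 `C#Cc1ccccc1NC(=O)CCc1cccc2c1B(O)OC2` carries ethynyl in place of methoxy on an aromatic carbon, ortho to a large group (ethynyl in place of methoxy on an aromatic carbon). For the measured compounds named here, the only measured step bearing on this place is large (a 19-fold lower number from compound 1 to compound 2 (1.27 log units; beyond the scatter)) and came with methoxy in place of hydrogen. No measurement shows how ethynyl behaves, so a moderate move towards a higher number is expected in this assay. The estimate means a 1.9-fold higher number from compound 2 to compound 3 (0.27 log units; within the scatter) and remains an expectation. For compound 3 the expected value is 3000 nM (range 700 nM to 13000 nM).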

Compound 3, half-maximal inhibitory concentration: 18000 nM
Compound 3: middle estimate off by 6.0-fold (0.78 log units), on the low side; measured number above the stated range.
By their numbers in this assay, from the lowest: compound 2; then compounds 3 and 1 (each within the scatter of the next).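

In this assay, the aromatic carbon ortho to a large group proves sensitive to the group it carries: ethynyl in place of methoxy gives an 11-fold higher number from compound 2 to compound 3 (1.05 log units; beyond the scatter), so the step seen with methoxy does not extend to this other group of equal heavy-atom count. Ethynyl in place of hydrogen gives a 1.7-fold lower number from compound 1 to compound 3 (0.22 log units; within the scatter), which leaves methoxy alone apart from the other two among these three compounds. Nothing available accounts for the gap between methoxy and ethynyl. The compounds shown leave open how a hydroxyl, an ethoxy or an amine on this carbon would compare with methoxy, and whether methoxy would give a similar step on another carbon of the same ring.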